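Sulfonyl Aryl Exchange in a Weakly Active Series

The source may hold more compounds than are shown below. What is called first, only, known or untested is meant among the compounds shown, and "the series" means these compounds.

Compound 1, `C=CCNC(=O)n1c(-c2ccc(OC)cc2)cc(=O)c2c(OC)cc(OC)cc21`: 12000 nM
Compound 2, `COc1ccc(-c2cc(=O)c3c(OC)cc(OC)cc3n2S(=O)(=O)c2cccc([N+](=O)[O-])c2)cc1`: > 39600 nM

Of the compounds shown here, two have been measured in a functional assay on KOPN-8 cells (Homo sapiens) for antiproliferative activity, with a stated time of 72 h; on this read-out higher numbers stand for an effect only at larger amounts of compound and lower numbers for an effect already at smaller amounts. Compound 1 `C=CCNC(=O)n1c(-c2ccc(OC)cc2)cc(=O)c2c(OC)cc(OC)cc21` gives 12000 nM in this assay. Compound 2 `COc1ccc(-c2cc(=O)c3c(OC)cc(OC)cc3n2S(=O)(=O)c2cccc([N+](=O)[O-])c2)cc1` is reported only as > 39600 nM, which is a limit of the assay and not a number. Of the two values shown, one therefore sits at the limit of > 39600 nM in this assay, at which 1 of the 2 values shown sits. Going by the values given here, no step between measured compounds is available, so the two values show only that compound 1 yields a number while compound 2 does not.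

Compound 3 `COc1ccc(-c2cc(=O)c3c(OC)cc(OC)cc3n2S(=O)(=O)c2ccc(C#N)cc2)cc1` has not yet been measured. It differs from compound 2 in one place: 4-cyanophenyl in place of 3-nitrophenyl on a sulfonyl sulfur. Since compound 2 stands at the limit, the change from compound 2 to compound 3 is expected to make no difference beyond the scatter in this assay, with an estimated step that the limit leaves unreadable from compound 2 to compound 3. Compound 3 is therefore expected to give about 40000 nM, within a range of 15000 nM to 100000 nM, and most likely to be reported again only as a limit.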

Compound 3, half-maximal effective concentration: > 17200 nM
Compound 3 was reported as a limit; the forecaster's own chance of this, stated with the estimate: 70%; the middle value does not contradict the limit.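

With 4-cyanophenyl in place of 3-nitrophenyl on a sulfonyl sulfur, compound 3 in this assay again yields a limit of the assay and not a number: the limit of > 17200 nM in this assay, at which 1 of the 3 values shown sits.

Going by these compounds alone, compound 2 and compound 3 thus both stand as limits, so the step between them cannot be read, and this exchange shows neither a gain nor a loss; what is new is only that a second aryl group on this sulfur also gives no number. The comparison with the allylcarbamoyl compound gives an at least 1.4-fold higher number from compound 1 to compound 3 (0.15 log units; that floor lies within the scatter), so this floor alone does not set compound 3 apart from compound 1, even though compound 1 alone yields a number.

As far as these compounds go, it remains open where the true values of compound 2 and compound 3 lie, and whether either would differ from compound 1 beyond the scatter. From the compounds shown here alone, it also remains open whether an amine or a carboxylic acid on the phenyl ring, or a simple methyl in place of the aryl group on the sulfonyl sulfur, would bring a number in this assay.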